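Swapping Bromo for Methoxy on the Shared Core

The compounds below may be only part of what the source reports. "The series", "measured", "known", "first", "only" and "open" are said of these compounds alone.

Measured in a functional assay on KYSE-450 cells (Homo sapiens) for inhibition, read by MTT assay, with a stated time of 48 h; on this read-out higher numbers stand for weaker inhibition and lower numbers for stronger inhibition:
Compound 1 `COc1ccc(CNc2cc(OC)c(OC)c(OC)c2)cc1Cl`: 47800 nM
Compound 2 `COc1cc(NCc2ccc(Br)cc2)cc(OC)c1OC`: > 80000 nM (a limit)

For compound 2, the entry > 80000 nM is a limit of the assay and not a number. Compound 3 `COc1ccc(CNc2cc(OC)c(OC)c(OC)c2)cc1` has not yet been measured. It differs from compound 2 by methoxy in place of bromo on an aromatic carbon, para to a large group: methoxy in place of bromo on an aromatic carbon.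

Among the compounds with values here, no measured step shows what this change does in this assay. Compound 1 also carries a methoxy and gives 47800 nM, so a small shift towards stronger inhibition is expected, possibly none beyond the scatter. The estimated change is an at least 1.4-fold lower number from compound 2 to compound 3 (0.16 log units; that floor lies within the scatter). For compound 3 the expected value is 55000 nM, with an estimated range from 22000 nM to 120000 nM.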

Compound 3, half-maximal inhibitory concentration: 4890 nM
The estimate for compound 3 lay 11-fold (1.05 log units) above the measured number; the measured number lies below the stated range.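

In this assay, methoxy on this aromatic carbon, para to a large group, has a far larger effect than compound 1 alone suggested: the swap for bromo gives an at least 16-fold lower number from compound 2 to compound 3 (1.21 log units; beyond the scatter). The entry for compound 2 is a limit and not a number: the limit of > 80000 nM in this assay, at which 1 of the 3 values shown sits.

The methoxy does not settle the outcome alone, as hydrogen in place of chloro gives a 9.8-fold lower number from compound 1 to compound 3 (0.99 log units; beyond the scatter), so the number stays high when chloro is present alongside the methoxy.

The compounds shown leave open whether this gain is specific to methoxy or would appear with other groups on the same carbon. An ethoxy group or an amine in that place would show how closely the result depends on methoxy itself.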